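The compounds below may be only part of what the source reports. "The series", "measured", "known", "first", "only" and "open" are said of these compounds alone.

Values in a functional assay on the whole organism with Scenedesmus acutus as the target; on this read-out lower numbers stand for stronger inhibition and higher numbers for weaker inhibition:
- compound 1 `CCOC(=O)c1cc(N2C(=O)C3=C(CCCC3)C2=O)c(F)cc1Cl`: 100 nM
- compound 2 `CCOC(=O)c1cc(N2C(=O)C3=C(CCCC3)C2=O)ccc1Cl`: 1380 nM
- compound 3 `CCCCOC(=O)c1cc(N2C(=O)C3=C(CCCC3)C2=O)c(F)cc1Cl`: 67.6 nM
- compound 4 `CCC(C)OC(=O)c1cc(N2C(=O)C3=C(CCCC3)C2=O)ccc1Cl`: not yet measured

Compound 2 gives the highest number of the three, beyond the scatter from both others. The nearer gap is a 14-fold higher number from compound 1 to compound 2 (1.14 log units; beyond the scatter). That step is hydrogen in place of fluoro, not a change in the ester chain, so it gives little guidance here.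

The change to compound 4 is ethyl in place of hydrogen on a saturated chain carbon bound to an oxygen next to a carbonyl group and a saturated chain carbon, which reads as ethoxycarbonyl to sec-butoxycarbonyl. The closest measured step is a 1.5-fold lower number from compound 1 to compound 3 (0.17 log units; within the scatter), and it lies within the scatter. It also adds an ethyl to the chain, but in a different place and in the presence of the fluoro group. Within the data shown here, no measured compound carries the sec-butoxycarbonyl group, so this comparison is only a loose one.

No step beyond the scatter is therefore expected in this assay, with a slight lean towards a lower number. The estimated step is a 1.4-fold lower number from compound 2 to compound 4 (0.14 log units; within the scatter). For compound 4 the expected value is 1000 nM, with an estimated range of 350 nM to 2800 nM.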

Compound 4, half-maximal inhibitory concentration: 794 nM
Compound 4: the middle estimate sits 1.3-fold (0.10 log units) above what was measured; the range from low to high includes it.
By their numbers in this assay, from the lowest: compounds 3 and 1 (each within the scatter of the next); then compounds 4 and 2 (each within the scatter of the next).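

Ethoxycarbonyl to sec-butoxycarbonyl in this assay gives a 1.7-fold lower number from compound 2 to compound 4 (0.24 log units; within the scatter), so ethyl on the saturated chain carbon bound to an oxygen next to a carbonyl group produces no step beyond the scatter. Among these compounds, the earlier ester change was seen only with the fluoro group present; this result shows the same outcome with hydrogen in its place. Across the two cores, the ester change therefore reads alike, and neither step approaches the size of the fluoro to hydrogen change: the same change on two cores in this assay, a 1.5-fold lower number (0.17 log units; within the scatter) from compound 1 to compound 3 and a 1.7-fold lower number (0.24 log units; within the scatter) from compound 2 to compound 4, 1.2-fold (0.07 log units) apart, within the scatter of two such steps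

Still open, going by these compounds, is whether a longer chain, a cyclohexyl ester or a carboxylic acid at this position would also stay within the scatter. Also open, on these data alone, is how sec-butoxycarbonyl reads on the fluoro-bearing core, where it would allow a direct test of the fluoro to hydrogen change with this ester.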